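Dropping the Phenyl from Compound 3: a Flat Step Expected

A few compounds are considered here, and "the series" means these few. Any claim that something is new, unique, unknown or untested is made for them only; others in the source may bear on it.

Of the compounds shown here, three built on one shared core have been measured in an assay on cells for inhibition of Voltage-dependent T-type calcium channel subunit alpha-1G (Homo sapiens), read by patch clamp; on this read-out higher numbers stand for weaker inhibition and lower numbers for stronger inhibition. Compound 1 `O=C(CC1c2ccccc2N=C(SCCCCCN2CCCC2)N1c1ccc(-c2ccccc2)cc1)NCc1ccc(F)cc1` gives 15000 nM. Compound 2 `O=C(CC1c2ccccc2N=C(SCCCCCN2CCCC2)N1c1ccccc1)NCc1ccc(F)cc1` gives 13500 nM. Compound 3 `O=C(CC1c2ccccc2N=C(SCCCCCN2CCCC2)N1c1ccc(-c2ccccc2)cc1)NCc1ccccc1` gives 660 nM, the lowest of the three numbers; compound 2 stands nearest to it, and its distance to both other compounds lies beyond the scatter. The step of a 23-fold lower number from compound 1 to compound 3 (1.36 log units; beyond the scatter) is large, whereas a 1.1-fold lower number from compound 1 to compound 2 (0.05 log units; within the scatter) stays within the scatter.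

Compound 4 `O=C(CC1c2ccccc2N=C(SCCCCCN2CCCC2)N1c1ccccc1)NCc1ccccc1` has not yet been measured. It differs from compound 3 by hydrogen in place of phenyl on an aromatic carbon. This same change has already been seen once among the measured compounds, in the step of a 1.1-fold lower number from compound 1 to compound 2 (0.05 log units; within the scatter), which remained within the scatter. On that single precedent, the step from compound 3 to compound 4 is expected to be of the same kind, with no shift beyond the scatter in this assay in either direction. Compound 4 is therefore expected to give about 650 nM, within a range of 250 nM to 1700 nM, which means an expected step of a 1.0-fold lower number from compound 3 to compound 4 (0.01 log units; within the scatter).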

Compound 4, half-maximal inhibitory concentration: 77000 nM
Compound 4: middle estimate off by 120-fold (2.07 log units), on the low side; measured number above the stated range.
By their numbers in this assay, from the lowest: compound 3; then compounds 2 and 1 (each within the scatter of the next); then compound 4.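

In this assay, the change from 4-phenylphenyl to phenyl turns out not to be silent on every core, as it gives a 120-fold higher number from compound 3 to compound 4 (2.07 log units; beyond the scatter), and the two readings of this change disagree: the same change on two cores in this assay, a 1.1-fold lower number (0.05 log units; within the scatter) from compound 1 to compound 2 and a 120-fold higher number (2.07 log units; beyond the scatter) from compound 3 to compound 4, 130-fold (2.11 log units) apart, beyond the scatter of two such steps Hydrogen in place of fluoro also changes direction with its surroundings, giving a 5.7-fold higher number from compound 2 to compound 4 (0.76 log units; beyond the scatter), and again the two readings disagree: the same change on two cores in this assay, a 23-fold lower number (1.36 log units; beyond the scatter) from compound 1 to compound 3 and a 5.7-fold higher number (0.76 log units; beyond the scatter) from compound 2 to compound 4, 130-fold (2.11 log units) apart, beyond the scatter of two such steps The effect of each change therefore depends on the group present at the other place, something the first three compounds could not show.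

These four compounds alone cannot tell whether this dependence extends to other groups at either place. From the compounds shown here alone, it remains open how a methyl or a methoxy on the same aromatic carbon, or a chloro in place of the fluoro, would read in this assay.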